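This account rests on a few compounds, and the source may have more. Where it says the series, first, only, none or still open, it means among the compounds named here.

In an assay on CHO cells for displacement of a labelled ligand from 5-hydroxytryptamine receptor 1B (Homo sapiens) (a lower number here means a stronger inhibitor, a higher number a weaker inhibitor), compound 2 `FC(F)(F)c1ccc(CN2CCN(CCCc3c[nH]c4ccc(-n5cnnc5)cc34)CC2)cc1` gives 282 nM, the highest of the two single numbers available; the nearest is compound 1 `c1coc(CN2CCN(CCCc3c[nH]c4ccc(-n5cnnc5)cc34)CC2)c1` with 18 nM, while compound 3 `NC(=O)C(c1ccccc1)N1CCN(CCCc2c[nH]c3ccc(-n4cnnc4)cc23)CC1` has several entries, 55 nM; 13 nM (2 entries). The spread within the several entries of compound 3 in this assay, 55 nM; 13 nM (2 entries) shows how far repeated numbers for one compound may wander. For the measured compounds named here, the only measured step that changes one place is a 16-fold higher number from compound 1 to compound 2 (1.19 log units; beyond the scatter), so what sits on the saturated chain carbon bound to the amine nitrogen in the ring can move the number strongly. Compound 4 `CN1CCN(CCCc2c[nH]c3ccc(-n4cnnc4)cc23)CC1` differs from compound 2 by hydrogen in place of 4-(trifluoromethyl)phenyl on a saturated chain carbon bound to an amine nitrogen in a ring, so the aromatic group is removed rather than exchanged. Going by the values given here, no measured step removes this group outright, so the step from compound 1 to compound 2 serves only as a guide to scale. With the furan-2-yl of compound 1 the number is lower than with the 4-(trifluoromethyl)phenyl of compound 2, and on that basis a further paring back in compound 4 is expected to give a lower number, a 4.7-fold lower number from compound 2 to compound 4 (0.67 log units; beyond the scatter), with wide uncertainty. Compound 4 is therefore estimated at 60 nM, within a range from 10 nM to 400 nM.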

Compound 4, half-maximal inhibitory concentration: 309 nM
The estimate for compound 4 lay 5.2-fold (0.71 log units) below the measured number; low and high end bracket the measured number.
By their numbers in this assay, from the lowest: compound 1; then compounds 2 and 4 (each within the scatter of the next).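

In this assay, hydrogen in place of 4-(trifluoromethyl)phenyl makes no real difference: a 1.1-fold higher number from compound 2 to compound 4 (0.04 log units; within the scatter). Hydrogen in place of furan-2-yl does, giving a 17-fold higher number from compound 1 to compound 4 (1.23 log units; beyond the scatter), so the lower number of compound 1 goes with the furan-2-yl group itself, while the larger aromatic group of compound 2 offers no gain over the plain methyl of compound 4, and a simple rule that less is better at this place does not hold. Repeated numbers for a single compound can wander, yet the step from furan-2-yl to hydrogen is larger than that wandering: the several entries of compound 3 in this assay, 55 nM; 13 nM (2 entries)

From the compounds shown here alone, whether the lower number belongs to furan-2-yl alone or is shared by other aromatic rings stays open. Thiophen-2-yl or unsubstituted phenyl on that carbon would speak to this, separating the effect of the ring from that of the trifluoromethyl group.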